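The source may hold more compounds than are shown below. What is called first, only, known or untested is meant among the compounds shown, and "the series" means these compounds.

Compound 1 `CCCCNc1nc(N)nc(C)c1CCCc1ccccc1` carries a butylamino group, an amino group and a methyl group on its core, with a three-carbon chain ending in a phenyl ring. In an assay on HEK293 cells for agonist activity at Toll-like receptor 8 (Homo sapiens), read by spectrophotometry (on this read-out lower numbers stand for an effect already at smaller amounts and higher numbers for an effect only at larger amounts of compound), compound 1 gives 749 nM. Compound 2 `CCCCNc1nc(N)nc(C)c1CCCCO` keeps the same core and chain but ends in a hydroxyl; in this assay compound 2 gives 1310 nM. The step of a 1.7-fold higher number from compound 1 to compound 2 (0.24 log units; within the scatter) is the only one measured so far, so compound 2's number sits alongside that of compound 1 rather than apart from it.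

Compound 3 `CCCCNc1nc(N)nc(C)c1C#C[Si](C)(C)C` changes the same position again: a group of 6 heavy atoms (5 carbon, 1 silicon; no ring) in place of a group of 5 heavy atoms (4 carbon, 1 oxygen; no ring), on an aromatic carbon. For the measured compounds named here, the one measured step, a 1.7-fold higher number from compound 1 to compound 2 (0.24 log units; within the scatter), bears on this only loosely, since it shows that swapping the end of the side chain left the number within the scatter; the change to compound 3 is larger, replacing the whole chain with a silicon-bearing alkyne, and no measured pair shows such a swap. On that basis, for compound 3 in this assay the step of a 1.5-fold lower number from compound 2 to compound 3 (0.16 log units; within the scatter) is expected, with the number estimated at 900 nM, in a range from 250 nM to 3500 nM.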

Compound 3, half-maximal effective concentration: 9240 nM
Beside the measured number, compound 3's estimate is 10-fold (1.01 log units) below it, outside the stated range (above it).
By their numbers in this assay, from the lowest: compounds 1 and 2 (each within the scatter of the next); then compound 3.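

In this assay, for the compounds shown here, replacing the 4-hydroxybutyl chain with the silicon-bearing alkyne gives a 7.1-fold higher number from compound 2 to compound 3 (0.85 log units; beyond the scatter) and is the first step in this set to lie beyond the scatter. The aromatic carbon ortho to the butylamino group and ortho to the methyl group is therefore sensitive to what it carries: changing only the end of the saturated chain left the number within the scatter, whereas replacing the whole chain means that a larger amount of compound is needed for the effect. This single swap alters several things at once, including the loss of the hydroxyl and the arrival of a triple bond and a silicon atom, and no measurement here ties the rise to any one of them or explains it.

As far as these compounds go, it remains open whether the triple bond or the silicon-bearing end matters more, and a plain ethynyl group or a saturated chain ending in the same silicon group would help separate the two. From the compounds shown here alone, it is also open how a chain ending in an amine or a carboxylic acid would read at this position.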